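Swapping an Amide Branch for a Thioether Chain

This account rests on a few compounds, and the source may have more. Where it says the series, first, only, none or still open, it means among the compounds named here.

Compound 1, `CCc1cc(C(C)=O)c(O)cc1OCCCCCCC#N`, gives 103% in an assay on isolated protein for inhibition of leukotriene B4 receptor 1 (Homo sapiens), tested at 10 uM; a lower number here means less inhibition, a higher number more inhibition at the concentration tested (going by the name of the read-out).
Compound 2, `CCc1cc(C(C)=O)c(O)cc1OCCCCCCCC(C)(C)C#N`, gives 66%.
Compound 3, `CCc1cc(C(C)=O)c(O)cc1OCCCC(C)(C)C(N)=O`, gives 92%.

Compound 3 stands second highest of the three numbers. The step of a number 11 percentage points lower from compound 1 to compound 3 (beyond the scatter) places it somewhat under the top of the set, while compound 2, with its value 66%, lies well under it.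

Compound 4, `CCc1cc(C(C)=O)c(O)cc1OCCCCCCSC`, is the next compound to be measured. It differs from compound 3 in one place: 3-(methylsulfanyl)propyl in place of 1-carbamoyl-1-methylethyl on a saturated chain carbon, three bonds along the chain from an oxygen on an aromatic ring. The branch and the amide of compound 3 are thus both gone, and a straight chain ending in a sulfur takes their place.

Among the compounds with values here, two measured steps bear on this. The step of a number 11 percentage points lower from compound 1 to compound 3 (beyond the scatter) shows a modest loss when the amide branch enters, and the step of a number 37 percentage points lower from compound 1 to compound 2 (beyond the scatter) shows a large loss when a branched, longer nitrile chain enters. In both cases the branched chain scores lower than the plain chain of compound 1. The change to compound 4 runs the other way, back to a plain chain, so a small rise or a step within the scatter is expected, as a number 3 percentage points higher from compound 3 to compound 4 (within the scatter). Compound 4 is therefore estimated at 95%, with a range from 75% to 105%.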

Compound 4, a percentage reported as inhibition, at one concentration (the size of the read-out at that concentration, not a potency): 71%
The estimate for compound 4 lay 24 percentage points above the measured number; the measured number lies below the stated range.
By their numbers in this assay, from the lowest: compounds 2 and 4 (each within the scatter of the next); then compound 3; then compound 1.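

In this assay the return to a straight chain does not bring the number back up: the step is a number 21 percentage points lower from compound 3 to compound 4 (beyond the scatter) and so the branched amide of compound 3 stands above this unbranched chain, which goes against the earlier picture of plain chains scoring higher. The more telling comparison is a number 32 percentage points lower from compound 1 to compound 4 (beyond the scatter) with only methylsulfanyl in place of cyano, six bonds along the chain from an oxygen on an aromatic ring, so an unbranched chain alone does not secure a high number and the group at its end matters a great deal. The step of a number 5 percentage points higher from compound 2 to compound 4 (within the scatter) leaves this sulfur chain level with the longer branched nitrile, and nothing measured here explains why the end group counts for so much.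

It stays open whether the amide or the two methyl groups of the branch carry the number of compound 3, since the two change together in every comparison shown. Also open, from the compounds shown here alone, is how a carboxylic acid or an amine at the end of the chain would compare with the nitrile of compound 1.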